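Working notes: carbonyl substituent swap in one series

The compounds below may be only part of what the source reports. "The series", "measured", "known", "first", "only" and "open" are said of these compounds alone.

Measured so far in an assay on isolated protein for inhibition of aldehyde dehydrogenase 1A1 (Homo sapiens), read by spectrophotometry, tested at 10 uM; a higher number here means more inhibition at the concentration tested (going by the name of the read-out), a lower number less inhibition:
compound 1 `O=C(C1CC1)N1CCN(Cc2nc3ccccc3n2Cc2ccccc2C(F)(F)F)CC1` gives 56.3%
compound 2 `Cc1cccc(Cn2c(CN3CCN(C(=O)c4cccs4)CC3)nc3ccccc32)c1` gives 60.8%
compound 3 `CC(C)CCn1c(OC2CCN(C(=O)C3CC3)CC2)nc2ccccc21` gives 56.4%

Compound 2 gives the largest of the three numbers, but the gaps to compound 3 and to compound 1 both lie within the usual scatter, so no order among the three can be read. The next compound, compound 4 `Cc1cccc(Cn2c(CN3CCN(C(=O)C4CCC4)CC3)nc3ccccc32)c1`, differs from compound 2 in one place: cyclobutyl in place of thiophen-2-yl on a carbonyl carbon. For the measured compounds named here, no measured pair differing in only one place exists, so the step has no precedent here; all three measured compounds sit in the same band despite different groups on that carbonyl carbon. The step of a number 5.8 percentage points lower from compound 2 to compound 4 (within the scatter) is expected to be none beyond the scatter. For compound 4 the estimate in this assay is 55%, with a range from 40% to 70%.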

Compound 4, a percentage reported as inhibition, at one concentration (the size of the read-out at that concentration, not a potency): 69.1%
For compound 4 the middle estimate is 14.1 percentage points below the measured one; the range from low to high includes it.
By their numbers in this assay, from the lowest: compounds 1, 3, 2 and 4 (each within the scatter of the next, the first and the last beyond it).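

Cyclobutyl in place of thiophen-2-yl on a carbonyl carbon gives a number 8.3 percentage points higher from compound 2 to compound 4 (within the scatter) in this assay and forms the first pair in the series that differs in one place. This position therefore accepts a four-membered non-aromatic ring of carbon only as well as a five-membered aromatic ring with one hetero atom, with no step beyond the scatter. No evidence bears on this result.

As far as these compounds go, whether an amine, a carboxylic acid or a longer chain on this carbonyl carbon stays in the same band remains open. One pair also leaves open whether the step would hold with other groups on the shared core.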